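A few compounds are considered here, and "the series" means these few. Any claim that something is new, unique, unknown or untested is made for them only; others in the source may bear on it.

Measured compounds:
compound 1, `CC1(C)CCc2cc(CNCc3ccccc3)c(O)cc2O1`: 22000 nM
compound 2, `CC1(C)CCc2cc(CNCCCc3ccccc3)c(O)cc2O1`: 6500 nM
compound 3, `CC1(C)C=Cc2cc(CNCc3ccccc3)c(O)cc2O1`: 57000 nM

In a toxicity assay on L6 cells (Rattus norvegicus) for inhibition, read by microscopy and resazurin assay, with a stated time of 70 h (a higher number here means a weaker inhibitor, a lower number a stronger inhibitor), compound 1 gives 22000 nM, compound 2 gives 6500 nM and compound 3 gives 57000 nM. Among the measured compounds shown here, the one counted change among the measured compounds is that from compound 1 to compound 2, (phenethyl in place of phenyl on a saturated chain carbon bound to an amine nitrogen), which made a 3.4-fold lower number from compound 1 to compound 2 (0.53 log units; beyond the scatter). Compound 3 and compound 1 share the same side chain on different cores; how the two cores differ is not broken down here. Compound 4, `CC1(C)C=Cc2cc(CNCCCc3ccccc3)c(O)cc2O1`, has not yet been measured in this assay. It differs from compound 3 by phenethyl in place of phenyl on a saturated chain carbon bound to an amine nitrogen, the same change at the same place as that from compound 1 to compound 2, so the pair compound 3 and compound 4 repeats that change on the core of compound 3. For the measured compounds named here, the expectation for compound 4 rests on that single earlier step alone, because a 3.4-fold lower number from compound 1 to compound 2 (0.53 log units; beyond the scatter) is the only time the change has been measured. The expected step is a 3.4-fold lower number from compound 3 to compound 4 (0.53 log units; beyond the scatter). Compound 4 is estimated at 17000 nM, expected to fall between 8000 nM and 36000 nM.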

Compound 4, half-maximal inhibitory concentration: 28000 nM
Estimate against measurement, compound 4: 1.6-fold (0.22 log units) below; low and high end bracket the measured number.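

In this assay, phenethyl in place of phenyl on a saturated chain carbon bound to an amine nitrogen gave a 2.0-fold lower number from compound 3 to compound 4 (0.31 log units; beyond the scatter), so the number fell on the core of compound 3 as it had on the core of compound 1. The two steps point the same way, and their sizes cannot be told apart: the same change on two cores in this assay, a 3.4-fold lower number (0.53 log units; beyond the scatter) from compound 1 to compound 2 and a 2.0-fold lower number (0.31 log units; beyond the scatter) from compound 3 to compound 4, 1.7-fold (0.22 log units) apart, within the scatter of two such steps

Among the compounds shown here, this shows that the change carried from one core to the other in this assay, with no measurable difference in its size, but it rests on only two pairs and does not show that the change would carry to any further core or to any other assay. The compounds shown leave open what a longer chain at the same place would do to the number on either core. They also leave open whether a carboxylic acid or a methoxy group on the phenyl ring would alter the step.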